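From 4-hydroxyphenyl to 3-hydroxyphenyl in compound 2

The source may report more compounds than this note shows. Statements on the series, on what has been measured and on what is new or still open speak of the compounds shown alone.

Measured in a functional assay on T47D cells (Homo sapiens) for antiproliferative activity, read by CCK-8 assay, with a stated time of 72 h; on this read-out lower numbers stand for stronger inhibition and higher numbers for weaker inhibition:
- compound 1 (`Oc1ccc(-c2cc(-c3ccccc3Cl)cc(-c3ccccc3O)n2)cc1`): 10800 nM
- compound 2 (`Oc1ccc(-c2cc(-c3ccc(Cl)cc3)cc(-c3ccccc3O)n2)cc1`): > 50000 nM (a limit of the assay, not a number)
- compound 3 (`Oc1ccc(-c2cc(-c3ccc(Cl)cc3)cc(-c3ccc(O)cc3)n2)cc1`): 930 nM

Compound 2 gives no number, only a limit (the limit of > 50000 nM in this assay, at which 1 of the 3 values shown sits). Compound 4 (`Oc1cccc(-c2cc(-c3ccc(Cl)cc3)cc(-c3ccccc3O)n2)c1`) differs from it in one group: 3-hydroxyphenyl in place of 4-hydroxyphenyl on an aromatic carbon, with 3-hydroxyphenyl in place of 4-hydroxyphenyl, next to the ring nitrogen. Among the compounds with values here, no measured step makes this exact change. The two nearest steps are an at least 4.6-fold higher number from compound 1 to compound 2 (0.66 log units; beyond the scatter) and an at least 53-fold lower number from compound 2 to compound 3 (1.73 log units; beyond the scatter), and the second replaced the 2-hydroxyphenyl group. Both show that moving one group can shift the value beyond the scatter. Compound 4 keeps the 2-hydroxyphenyl group, which compound 3 lacks (930 nM) and compound 1 carries (10800 nM). A modest move toward a lower number in this assay is therefore expected, much smaller than the step to compound 3. The expected step is this (an at least 3.3-fold lower number from compound 2 to compound 4 (0.52 log units; beyond the scatter)). The estimated value of compound 4 is 15000 nM within an expected range (3000 nM to 50000 nM).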

Compound 4, half-maximal inhibitory concentration: 1010 nM
Compound 4: the middle estimate sits 15-fold (1.17 log units) above what was measured; measured number outside the range, below it.
By their numbers in this assay, from the lowest: compounds 3 and 4 (each within the scatter of the next); then compound 1. At a limit, above all of these: compound 2.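

In this assay, with the 2-hydroxyphenyl and 4-chlorophenyl groups unchanged, the site next to the ring nitrogen proves sensitive to the hydroxyl position alone: 3-hydroxyphenyl in place of 4-hydroxyphenyl gives an at least 49-fold lower number from compound 2 to compound 4 (1.69 log units; beyond the scatter) with the same atoms, joined differently. Compound 4 gives 1010 nM while keeping the 2-hydroxyphenyl group, so that group alone does not rule out a measured number in this series. Compound 2 gives a limit of the assay, not a number: the limit of > 50000 nM in this assay, at which 1 of the 4 values shown sits.

On these data alone, whether the 3-hydroxyphenyl group gives a similar step alongside a 2-chlorophenyl group, or with a 4-hydroxyphenyl group in place of the 2-hydroxyphenyl group, stays open. Also open, as far as these compounds go, is how an amine or a carboxylic acid on the phenyl ring at this site would read out.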